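Amide nitrogen substituent: benzyl replaced by 2,5-dimethoxyphenyl

A few compounds are considered here, and "the series" means these few. Any claim that something is new, unique, unknown or untested is made for them only; others in the source may bear on it.

In an ADME assay on HCT-116 cells (Homo sapiens) for cytotoxicity, read by MTT assay, with a stated time of 72 h (a lower number here means a stronger inhibitor, a higher number a weaker inhibitor), compound 2 `O=C(NCc1ccccc1)c1cccc(/C=C2\CC(=O)N(c3ccccc3)C2=O)c1` gives only the assay limit, > 100000 nM. Compound 1 `COc1ccc(NC(=O)c2cccc(/C=C3\CC(=O)N(c4ccccc4)C3=O)c2)c(C)c1` likewise gives only the limit, > 100000 nM. The step that the two limits leave unreadable from compound 1 to compound 2 is therefore not readable. Compound 3 `COc1ccc(OC)c(NC(=O)c2cccc(/C=C3\CC(=O)N(c4ccccc4)C3=O)c2)c1` differs from compound 2 by 2,5-dimethoxyphenyl in place of benzyl on an amide-type nitrogen. Within the data shown here, no measured step bears on this change, since both values shown sit at the limit of > 100000 nM in this assay, at which 2 of the 2 values shown sit. With nothing pointing either way, the expected step is a number no higher from compound 2 to compound 3 (the limit leaves the size open), within the scatter. Compound 3 is therefore expected at 100000 nM, with a range of 50000 nM to 300000 nM, most likely again reported only as a limit.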

Compound 3, half-maximal inhibitory concentration: > 100000 nM
Compound 3: no number, only a limit; the forecaster's own chance of this, stated with the estimate: 85%; the middle value lies on the limit itself.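

No step can be read among compound 1, compound 2 and compound 3 in this assay, as each gives only a limit: the limit of > 100000 nM in this assay, at which 3 of the 3 values shown sit.

From the compounds shown here alone, how the benzyl, 4-methoxy-2-methylphenyl and 2,5-dimethoxyphenyl groups on the amide-type nitrogen rank against one another remains open.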